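Swapping the aryl group on the shared core

The source may hold more compounds than are shown below. What is called first, only, known or untested is meant among the compounds shown, and "the series" means these compounds.

Compound 1 `Cc1ccccc1C1CC(c2ccc(OCc3ccccc3)cc2)=NN1c1ccc(S(N)(=O)=O)cc1` is the best tolerated of three compounds in an ADME assay on Vero 76 cells (Chlorocebus sabaeus) for cytotoxicity, read by MTT assay, with a stated time of 96 h (a higher number here means that more compound is tolerated, a lower number that less compound is tolerated), where compound 1 gives 100000 nM. Compound 2 `Cc1ccccc1C1CC(c2ccc(Oc3ccccc3)cc2)=NN1c1ccc(S(N)(=O)=O)cc1` gives 90000 nM, and compound 3 `Cc1ccccc1C1CC(c2ccccc2)=NN1c1ccc(S(N)(=O)=O)cc1` gives 24000 nM; the steps are a 1.1-fold lower number from compound 1 to compound 2 (0.05 log units; within the scatter) and a 4.2-fold lower number from compound 1 to compound 3 (0.62 log units; beyond the scatter). Compound 4 `NS(=O)(=O)c1ccc(N2N=C(c3ccc(OCc4ccccc4)cc3)CC2c2cccc(F)c2)cc1` differs from compound 1 in one place: 3-fluorophenyl in place of 2-methylphenyl on a saturated ring carbon. Among the measured compounds shown here, none of the measured steps touches this saturated ring carbon; they all alter the other aromatic ring, where the swap from benzyl to phenyl hardly mattered and only removal of the whole group shifted the number. Without a direct precedent, only a small step is expected, a 1.3-fold lower number from compound 1 to compound 4 (0.10 log units; within the scatter), so compound 4 is estimated at 80000 nM, with a range from 30000 nM to 150000 nM.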

Compound 4, half-maximal cytotoxic concentration: 90000 nM
For compound 4 the middle estimate is 1.1-fold (0.05 log units) below the measured one; low and high end bracket the measured number.
By their numbers in this assay, from the lowest: compound 3; then compounds 2, 4 and 1 (each within the scatter of the next).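

In this assay, putting 3-fluorophenyl in place of 2-methylphenyl on the saturated ring carbon gives a 1.1-fold lower number from compound 1 to compound 4 (0.05 log units; within the scatter). Among the compounds shown here, this is the first measured change at this position, and it shows that, with the benzyloxy group kept, one substituted phenyl ring can replace the other here without a shift beyond the scatter. No available evidence explains why the two groups give such similar numbers.

From the compounds shown here alone, whether the position would accept a group other than a substituted phenyl, such as an amine or a carboxylic acid, remains open. Also open, going by these compounds, is whether the same swap would behave alike on compound 2 or compound 3.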